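The source may hold more compounds than are shown below. What is called first, only, known or untested is meant among the compounds shown, and "the series" means these compounds.

Of the compounds shown here, two built on a shared core have been measured so far. In a functional assay on BT-474 cells (Homo sapiens) for inhibition, read by fluorescence, with a stated time of 72 h (a higher number here means a weaker inhibitor of growth, a lower number a stronger inhibitor of growth), compound 1 (`COc1ccc(Cn2cnc3c(Nc4cccc(Cl)c4)nc(N[C@H]4CC[C@H](N)CC4)nc32)cc1`) gives 8200 nM and compound 2 (`CC(C)CCn1cnc2c(NCc3cccc(Cl)c3)nc(N[C@H]3CC[C@H](N)CC3)nc21`) gives 6600 nM on the same read-out. These two values lie within the scatter of each other, so compound 2 stands level with compound 1 even though the two structures differ in more than one place.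

Compound 3 (`CC(C)CCn1cnc2c(Nc3cccc(Cl)c3)nc(N[C@H]3CC[C@H](N)CC3)nc21`) keeps the rest of compound 2 and changes one group. The change is 3-chlorophenyl in place of 3-chlorobenzyl on a nitrogen on an aromatic ring and, in words, 3-chlorophenyl comes in place of 3-chlorobenzyl on a nitrogen on an aromatic ring. For the measured compounds named here, no measured pair isolates this change, so the data give no direct guide to it. Compound 1 already carries the (3-chlorophenyl)amino group and sits at 8200 nM in this assay on a different remainder, which offers no sign of a large shift. The expected step (a 1.1-fold lower number from compound 2 to compound 3 (0.04 log units; within the scatter)) is therefore small and is not expected to go beyond the scatter. In this assay compound 3 is estimated at 6000 nM with an expected range of values (2500 nM to 14000 nM).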

Compound 3, concentration for 50% growth inhibition: 3800 nM
Beside the measured number, compound 3's estimate is 1.6-fold (0.20 log units) above it; the range from low to high includes it.
By their numbers in this assay, from the lowest: compounds 3, 2 and 1 (each within the scatter of the next, the first and the last beyond it).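

In this assay, for the compounds shown here, compound 2 and compound 3 form the first pair that isolates the group on a nitrogen on an aromatic ring, and the step, a 1.7-fold lower number from compound 2 to compound 3 (0.24 log units; within the scatter), shows that 3-chlorophenyl and 3-chlorobenzyl cannot be told apart there in this read-out. Going by these compounds alone, with the (3-chlorophenyl)amino group held the same, compound 1 and compound 3 isolate a second place, the saturated chain carbon bound to an aromatic nitrogen, where isobutyl in place of 4-methoxyphenyl gives a 2.2-fold lower number from compound 1 to compound 3 (0.33 log units; beyond the scatter), a modest step and the only one in these pairs that passes the scatter. Nothing available offers an explanation for either step.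

The compounds shown leave open whether a longer chain linking the ring to that nitrogen, as in 2-(3-chlorophenyl)ethyl, would also stay level with these two groups, and whether a nitrile in place of the chlorine would change the reading. They also leave open how groups other than isobutyl and 4-methoxyphenyl, such as cyclopentyl or a carboxylic acid on a short chain, would fare at the saturated chain carbon.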